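The compounds below may be only part of what the source reports. "The series", "measured", "known", "first", "only" and "open" are said of these compounds alone.

Working notes on the series, following the move from compound 1 to compound 4 in a functional assay on SMMC-7721 cells (Homo sapiens) for cytotoxicity, read by MTT assay, with a stated time of 4 days; a lower number here means a stronger inhibitor, a higher number a weaker inhibitor.

Compound 1 is `C=C1C[C@]23C[C@@]1(O)CC[C@@H]2c1cccc(C)c1[C@@H]3Cn1cc(-c2ccc(C)cc2)nn1`. In this assay compound 1 gives only a limit, > 20000 nM, and no number. Compound 2, `COc1ccc(-c2cn(C[C@H]3c4c(ccc(O)c4C)[C@@H]4CC[C@@]5(C)C[C@]43CC5=O)nn2)cc1`, likewise returns only a limit in this assay, > 20000 nM. For the measured compounds named here, compound 3, `C=C1C[C@]23C[C@@]1(O)CC[C@H]2c1cc(Br)c(O)c(C)c1[C@@H]3Cn1cc(-c2ccc(Cl)cc2)nn1`, is the single compound with a number: in this assay compound 3 gives 19100 nM. Compound 1 thus stands at the limit of > 20000 nM in this assay, at which 2 of the 3 values shown sit. On these numbers nothing separates compound 1 from compound 2. Going by the values given here, no two measured compounds differ in one place, so no single-change step is known.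

Compound 4 is `C=C1C[C@]23C[C@@]1(O)CC[C@@H]2c1cccc(C)c1[C@@H]3Cn1cc(-c2ccccn2)nn1`. It differs from compound 1 by pyridin-2-yl in place of 4-methylphenyl on an aromatic carbon. Among the compounds with values here, with no measured step to lean on, and compound 1 sitting at a limit, the change is expected to shift compound 4 by no more than the scatter, most probably leaving it at a limit again, which is what the expected step that the limit leaves unreadable from compound 1 to compound 4 means. The estimate for compound 4 in this assay is 25000 nM, expected to fall between 8000 nM and 80000 nM.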

Compound 4, half-maximal inhibitory concentration: > 20000 nM
Compound 4: only a limit was reported (the forecaster's own chance of this, stated with the estimate: 70%); the middle value does not contradict the limit.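

In this assay compound 4 gives only a limit, > 20000 nM. For the compounds shown here, compound 1 also gives only a limit, so no step from compound 1 to compound 4 can be read. The compounds shown leave open whether pyridin-2-yl in place of 4-methylphenyl changes cytotoxicity at all.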